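This account rests on a few compounds, and the source may have more. Where it says the series, first, only, none or still open, it means among the compounds named here.

Three compounds have been measured in an ADME assay on Huh7.5.1 cells (Homo sapiens) for cytotoxicity, read by ATP content, with a stated time of 48 h; on this read-out higher numbers stand for lower toxicity in this test and lower numbers for higher toxicity in this test:

compound 1 `Cc1ccc(C)c(-c2nc(CN3CCC(C(=O)NCCCN4C[C@H](C)C[C@H](C)C4)CC3)c(C)o2)c1` gives 4070 nM
compound 2 `Cc1ccccc1-c1nc(CN2CCC(C(=O)NCCCN3CC(C)(C)CC(C)(C)C3)CC2)c(C)o1` gives 4380 nM
compound 3 `Cc1oc(-c2ccc(Cl)c(Cl)c2)nc1CN1CCC(C(=O)NCCCN2C[C@H](C)C[C@H](C)C2)CC1` gives 3170 nM

Compound 2 sits at the top of these three numbers, though its gaps to compound 1 and to compound 3 both fall within the usual scatter. Compound 4 `Cc1ccccc1-c1nc(CN2CCC(C(=O)NCCN3C[C@H](C)C[C@H](C)C3)CC2)c(C)o1` is not yet measured. It differs from compound 2 in one place: a group of 8 heavy atoms (7 carbon, 1 nitrogen; one six-membered non-aromatic ring with 1 hetero atom) in place of a group of 11 heavy atoms (10 carbon, 1 nitrogen; one six-membered non-aromatic ring with 1 hetero atom), on a saturated chain carbon, two bonds along the chain from an amide-type nitrogen. Within the data shown here, the only measured step, a 1.3-fold lower number from compound 1 to compound 3 (0.11 log units; within the scatter), changes the aromatic group rather than the chain or the saturated ring, so no measured step bears directly on this change. With nothing pointing either way, compound 4 is expected to show a 1.1-fold lower number from compound 2 to compound 4 (0.04 log units; within the scatter), and its estimated value is 4000 nM within the range 2000 nM to 8000 nM.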

Compound 4, half-maximal cytotoxic concentration: 24400 nM
The estimate for compound 4 lay 6.1-fold (0.79 log units) below the measured number; the whole stated range lies below it.
By their numbers in this assay, from the lowest: compounds 3, 1 and 2 (each within the scatter of the next); then compound 4.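

Measured by (this assay), placing 3,5-dimethylpiperidin-1-yl in the group of 11 heavy atoms' stead, on a saturated chain carbon, two bonds along the chain from an amide-type nitrogen, gives a real change (a 5.6-fold higher number from compound 2 to compound 4 (0.75 log units; beyond the scatter)). Among these compounds, the aromatic step (a 1.3-fold lower number from compound 1 to compound 3 (0.11 log units; within the scatter)) stayed within the scatter, so this is the first sign that this end of the molecule can move the number. No measurement shown explains the change.

A plain piperidine or a morpholine at this place could show how much depends on the ring itself. As far as these compounds go, whether the step holds with other aromatic groups also remains open.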